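Amide variation: cyclobutyl to methoxymethyl, efficacy outlook

The compounds below may be only part of what the source reports. "The series", "measured", "known", "first", "only" and "open" are said of these compounds alone.

Compound 1 `C/C=C/C(=O)Nc1c(C(O)(C(F)(F)F)C(F)(F)F)ccc2ccccc12` and compound 2 `O=C(Nc1c(C(O)(C(F)(F)F)C(F)(F)F)ccc2ccccc12)C1CCC1` share one core and differ only in the group on the carbonyl carbon. In a functional assay (Sus scrofa) with sulfonylurea receptors; K-ATP channels (Homo sapiens) as the target (on this read-out higher numbers stand for larger maximal responses and lower numbers for smaller maximal responses), compound 1 gives 96%, and in the same read-out compound 2 gives 97%. The step of a number 1 percentage points higher from compound 1 to compound 2 (within the scatter) shows that this exchange left the maximal response essentially where it was. Among the compounds with values here, compound 2 holds the higher of the two numbers, with compound 1 as its only neighbour and within the scatter, so no order between them can be claimed.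

Compound 3 `COCC(=O)Nc1c(C(O)(C(F)(F)F)C(F)(F)F)ccc2ccccc12` differs from compound 2 by methoxymethyl in place of cyclobutyl on a carbonyl carbon. Within the data shown here, the one measured step that bears on this place, a number 1 percentage points higher from compound 1 to compound 2 (within the scatter), stayed within the scatter. Among the measured compounds shown here, that step swapped a chain for a ring; the present change removes the ring for a short chain with one hydrogen-bond acceptor, and no measured step covers such an exchange. Both known values lie near the top of the scale, leaving little room upward. The expected step is a number 4 percentage points lower from compound 2 to compound 3 (within the scatter), nothing beyond the scatter. Compound 3 is estimated at 93%, with a range of 80% to 101%.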

Compound 3, largest response reached (reported as efficacy), in percent of the reference or control that the assay uses: 93%
The estimate for compound 3 equals the measured number at the digits printed; the range from low to high includes it.
By their numbers in this assay, from the lowest: compounds 3, 1 and 2 (each within the scatter of the next).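

In this assay the step of a number 4 percentage points lower from compound 2 to compound 3 (within the scatter) and the step of a number 3 percentage points lower from compound 1 to compound 3 (within the scatter) both stay within the scatter, so no order among the three compounds can be claimed. The earlier pair carried only carbon groups on the carbonyl carbon, whereas methoxymethyl brings in an oxygen and the one hydrogen-bond acceptor counted for this change, and it leaves no ring at this place. Among these compounds, therefore, neither the four-membered ring of cyclobutyl nor an all-carbon group is needed to keep the maximal response at this level, although no measurement shown here accounts for why the read-out holds across these groups.

On these data alone, whether this holds for an aminomethyl group, a carboxylic acid or a longer chain such as hexyl on the same carbonyl carbon remains open. Also open is whether methoxymethyl in place of cyclobutyl gives a step within the scatter on any core other than the shared core of these compounds.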